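The source may report more compounds than this note shows. Statements on the series, on what has been measured and on what is new or still open speak of the compounds shown alone.

Three compounds that share one core have been examined in an ADME assay on microsomes from liver (Rattus norvegicus) for metabolic stability, read by mass spectrometry, using NADPH, with a stated time of 10 min; a higher number here means that more of the compound is left, a lower number that less of the compound is left. Compound 1 `CCCCc1[nH]c(=O)c(-c2nc(Cc3ccccc3)no2)c(O)c1-c1c(OC)cccc1OC` gives 54%, compound 2 `CCOCc1[nH]c(=O)c(-c2nnc(Cc3ccc(Cl)cc3)o2)c(O)c1-c1c(OC)cccc1OC` gives 74%, and compound 3 `CCCCc1[nH]c(=O)c(C(=O)OCC)c(O)c1-c1c(OC)cccc1OC` gives 24%. Compound 2 therefore stands highest of the three: compound 1 lies nearest, beyond the scatter below it, and compound 3 furthest, well beyond the scatter.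

The next compound, compound 4 `CCCCc1[nH]c(=O)c(-c2nnc(Cc3ccc(Cl)cc3)o2)c(O)c1-c1c(OC)cccc1OC`, differs from compound 2 in one place: propyl in place of ethoxy on a saturated chain carbon bound to an aromatic carbon. Among the measured compounds shown here, no step between measured compounds shows how this exchange alone acts, but compound 1 also carries a butyl chain and gives 54%, beyond the scatter below compound 2. A moderate fall beyond the scatter is therefore expected, a number 16 percentage points lower from compound 2 to compound 4 (beyond the scatter). Compound 4 is expected to leave 58% of the compound, in a range from 40% to 75%.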

Compound 4, percent of the compound remaining: 22%
Compound 4: the middle estimate sits 36 percentage points above what was measured; measured number outside the range, below it.
By their numbers in this assay, from the lowest: compounds 4 and 3 (each within the scatter of the next); then compound 1; then compound 2.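

In this assay, the exchange of ethoxymethyl for butyl, with the rest of the molecule unchanged, gives a number 52 percentage points lower from compound 2 to compound 4 (beyond the scatter), a large step. Among the compounds shown here, this is the first direct reading of this place, and it shows that the chain on this carbon alone can move the number by much more than the scatter. The compounds shown offer no measurement that explains the fall.

As far as these compounds go, it remains open whether a shorter methoxymethyl chain or an amine on the same carbon would keep the higher number. From the compounds shown here alone, it also remains open whether this exchange acts the same way with other groups on the shared core.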